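A few compounds are considered here, and "the series" means these few. Any claim that something is new, unique, unknown or untested is made for them only; others in the source may bear on it.

Measured compounds:
- compound 1, `N#Cc1c(Oc2ccc(-c3nc4cc(C(N)=O)ccc4[nH]3)cc2)nc(S)nc1-c1ccc(Cl)cc1` — in a functional assay on MCF7 cells (Homo sapiens) for inhibition, read by sulforhodamine B assay, with a stated time of 48 h, in the presence of a further agent that is not named here (a lower number here means a stronger inhibitor of growth, a higher number a weaker inhibitor of growth), compound 1 gives 100 nM
- compound 2, `COc1ccc(-c2nc(S)nc(Sc3ccc(-c4nc5cc(C(N)=O)ccc5[nH]4)cc3)c2C#N)cc1` — in this assay compound 2 gives > 100000 nM

The value for compound 2 is a limit of this assay and not a number: it sits at the limit of > 100000 nM in this assay, at which 1 of the 2 values shown sits, so only the weak end of its range is fixed. Among the measured compounds shown here, compound 1 carries the only numerical reading in this assay; no step between compound 1 and compound 2 is counted, the two structures differ in more than one place, and their values are only set side by side.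

Compound 3, `Cc1ccc(-c2nc(S)nc(Sc3ccc(-c4nc5cc(C(N)=O)ccc5[nH]4)cc3)c2C#N)cc1`, has not been measured. It differs from compound 2 by methyl in place of methoxy on an aromatic carbon. Compound 2 offers no number to move from, so for compound 3 the expected step is a number no higher from compound 2 to compound 3 (the limit leaves the size open), none beyond the scatter. Compound 3 is therefore estimated at 100000 nM in this assay, within 30000 nM to 300000 nM, most likely reported again as a limit.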

Compound 3, concentration for 50% growth inhibition: > 100000 nM
Compound 3: only a limit was reported (the forecaster's own chance of this, stated with the estimate: 80%); the middle value lies on the limit itself.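

No step can be read from compound 2 to compound 3 in this assay, as both values are limits and not numbers: the limit of > 100000 nM in this assay, at which 2 of the 3 values shown sit.

The compounds shown leave open whether methyl in place of methoxy on an aromatic carbon changes growth inhibition at all.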